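This account rests on a few compounds, and the source may have more. Where it says the series, first, only, none or still open, it means among the compounds named here.

Measured compounds:
Compound 1, `O=c1nc(N2CCC(c3ccccc3)CC2)sc2c([N+](=O)[O-])cc(C(F)(F)F)cc12`, in an ADME assay on K562 cells (Homo sapiens) for antiproliferative activity, with a stated time of 72 h; a higher number here means a weaker inhibitor of growth, a lower number a stronger inhibitor of growth: > 50000 nM, a limit of the assay.
Compound 2, `O=c1nc(NCc2ccc3c(c2)OCCO3)sc2c([N+](=O)[O-])cc(C(F)(F)F)cc12`, in this assay: 37000 nM.
Compound 3, `C[C@H]1COC2(CCN(c3nc(=O)c4cc(C(F)(F)F)cc([N+](=O)[O-])c4s3)CC2)O1`, in this assay: 11000 nM.

Among the two numbers actually reported, compound 2 stands highest; its nearest neighbour, compound 3, lies lower by a gap beyond the usual scatter. For compound 1 the assay reports only a limit, (the limit of > 50000 nM in this assay, at which 1 of the 3 values shown sits), and not a number. For the measured compounds named here, no two of the measured compounds differ from each other in a single place, so no measured step can be drawn from them.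

Compound 4, `Cc1ccc(CNc2nc(=O)c3cc(C(F)(F)F)cc([N+](=O)[O-])c3s2)n1C`, has not yet been measured. It differs from compound 2 in one place: 1,5-dimethyl-1H-pyrrol-2-yl in place of 2,3-dihydro-1,4-benzodioxin-6-yl on a saturated chain carbon bound to a nitrogen on an aromatic ring. The group that leaves and the group that enters both sit on the same saturated chain carbon bound to the ring nitrogen, and the shared core is untouched. Going by the values given here, with no measured step to rest on, the expectation is that this exchange moves the value little, and not clearly beyond the scatter in either direction. Compound 4 is therefore expected to give 30000 nM in this assay, within a range of 10000 nM to 80000 nM. The step this estimate means, a 1.2-fold lower number from compound 2 to compound 4 (0.09 log units; within the scatter), is expected to stay within the scatter.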

Compound 4, concentration for 50% growth inhibition: 21000 nM
Beside the measured number, compound 4's estimate is 1.4-fold (0.15 log units) above it; the range from low to high includes it.
By their numbers in this assay, from the lowest: compounds 3, 4 and 2 (each within the scatter of the next, the first and the last beyond it). At a limit, above all of these: compound 1.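

At the saturated chain carbon bound to a nitrogen on an aromatic ring, the compounds now offer their first measured step: in this assay, 1,5-dimethyl-1H-pyrrol-2-yl in place of 2,3-dihydro-1,4-benzodioxin-6-yl gives a 1.8-fold lower number from compound 2 to compound 4 (0.25 log units; within the scatter). The exchange replaces one six-membered non-aromatic ring and one six-membered aromatic ring of carbon only with one five-membered aromatic ring, and the two oxygen atoms of the leaving group are gone, yet the step stays within the scatter, so at this place these two groups cannot be told apart by this read-out. Nothing measured here gives a reason why the two groups read alike.

Both groups compared at this chain carbon contain an aromatic ring, so the compounds shown leave open how the read-out would respond to a piperidine, a carboxylic acid or a plain methyl group at the same place. On these data alone, compound 1 and compound 3 differ from compound 2 and compound 4 in more than one place, so whether this step would hold with another group on the shared core also remains open.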